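Compound 3 to compound 4: methyl to hydrogen

The source may report more compounds than this note shows. Statements on the series, on what has been measured and on what is new or still open speak of the compounds shown alone.

Measured in a functional assay on thoracic aorta (Rattus norvegicus, strain Wistar), with a stated time of 15 min; a higher number here means that more compound is needed for the effect, a lower number that less compound is needed:
- compound 1 `CC(NC(=O)NS(=O)(=O)c1ccc(Cl)cc1)c1ccccc1OCc1ccccc1`: 157000 nM
- compound 2 `CC(NC(=O)NS(=O)(=O)c1ccccc1)c1cc(Br)ccc1OCc1ccccc1`: 130000 nM
- compound 3 `CC(NC(=O)N(C)S(=O)(=O)c1ccccc1)c1ccccc1OCc1ccccc1`: 21700 nM

Compound 3 has the lowest number of the three, and its gaps to compound 1 and compound 2 are both beyond the scatter. Compound 1 and compound 2 lie within the scatter of each other. Both carry hydrogen on the amide-type nitrogen where compound 3 carries methyl, but each also differs from compound 3 elsewhere, so the series offers no measured single-change comparison.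

Compound 4 `CC(NC(=O)NS(=O)(=O)c1ccccc1)c1ccccc1OCc1ccccc1` differs from compound 3 by hydrogen in place of methyl on an amide-type nitrogen. It shares that hydrogen with compound 1 at 157000 nM and compound 2 at 130000 nM, so a number near theirs is expected. In this assay the expected change is a 5.5-fold higher number from compound 3 to compound 4 (0.74 log units; beyond the scatter), toward a higher number and beyond the scatter. For compound 4 the estimated value is 120000 nM, with an expected range of 50000 nM to 290000 nM.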

Compound 4, half-maximal effective concentration: > 200000 nM
Compound 4 was reported as a limit (the forecaster's own chance of this, stated with the estimate: 15%); middle value at least 1.6-fold (0.22 log units) from the limit.
By their numbers in this assay, from the lowest: compound 3; then compounds 2 and 1 (each within the scatter of the next). At a limit, above all of these: compound 4.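

In this assay compound 4 gives > 200000 nM as a limit of the assay. Hydrogen in place of methyl on an amide-type nitrogen gives an at least 9.2-fold higher number from compound 3 to compound 4 (0.96 log units; beyond the scatter) as the first single-change reading at this position, a step that is at least modest, so methyl there goes with the lower number. The size of that step remains a floor because the reading stops at a limit: the limit of > 200000 nM in this assay, at which 1 of the 4 values shown sits.

Hydrogen in place of bromo on an aromatic carbon gives an at least 1.5-fold higher number from compound 2 to compound 4 (0.18 log units; that floor lies within the scatter), and hydrogen in place of chloro on an aromatic carbon gives an at least 1.2-fold higher number from compound 1 to compound 4 (0.10 log units; that floor lies within the scatter). On these data alone, neither step can be read, as their floors lie within the scatter, so the effect of the chloro and bromo groups on the aromatic carbon stays open. Also open, as far as these compounds go, is whether ethyl or a longer chain on that nitrogen would match methyl in compound 3.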